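From 4-bromophenyl to 3,4-dimethoxyphenyl under an acetyl group

A few compounds are considered here, and "the series" means these few. Any claim that something is new, unique, unknown or untested is made for them only; others in the source may bear on it.

Compound 1 `COc1ccc(-c2c[nH]c(=O)n2-c2cc(OC)c(OC)c(OC)c2)cc1OC`: 38800 nM
Compound 2 `COc1ccc(-c2c[nH]c(=O)n2-c2cc(OC)c(OC)c(OC)c2)cc1[N+](=O)[O-]`: 14300 nM
Compound 3 `COc1cc(-n2c(-c3ccc(Br)cc3)cn(C(C)=O)c2=O)cc(OC)c1OC`: 200 nM

All three were tested in a functional assay on HL-60 cells (Homo sapiens) for cytotoxicity, read by MTT assay, with a stated time of 48 h; on this read-out lower numbers stand for stronger inhibition and higher numbers for weaker inhibition. Compound 3 has the lowest number of the three, at 200 nM. Compound 4 `COc1ccc(-c2cn(C(C)=O)c(=O)n2-c2cc(OC)c(OC)c(OC)c2)cc1OC` keeps its acetyl group but carries 3,4-dimethoxyphenyl in place of 4-bromophenyl on an aromatic carbon. Within the data shown here, the only measured step at this aryl group is a 2.7-fold lower number from compound 1 to compound 2 (0.43 log units; beyond the scatter), which is modest and was seen without the acetyl group. Among the measured compounds shown here, no measured pair tests bromine. Compound 1, which has the 3,4-dimethoxyphenyl group, lies on the higher side of that step. A modest rise is therefore expected in this assay. The expected step is a 2.5-fold higher number from compound 3 to compound 4 (0.40 log units; beyond the scatter). For compound 4 the estimate is 500 nM, with an expected range of 120 nM to 2500 nM.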

Compound 4, half-maximal inhibitory concentration: 12200 nM
The estimate for compound 4 lay 24-fold (1.39 log units) below the measured number; measured number above the stated range.
By their numbers in this assay, from the lowest: compound 3; then compounds 4 and 2 (each within the scatter of the next); then compound 1.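

In this assay, this aryl position proves far more sensitive under the acetyl group than the earlier nitro and methoxy pair suggested: 3,4-dimethoxyphenyl in place of 4-bromophenyl gives a 61-fold higher number from compound 3 to compound 4 (1.79 log units; beyond the scatter). Acetyl in place of hydrogen on the aromatic nitrogen, with 3,4-dimethoxyphenyl kept, gives only a 3.2-fold lower number from compound 1 to compound 4 (0.50 log units; beyond the scatter), so acetyl alone does not bring the number close to that of compound 3. Nothing available explains the size of either step. From the compounds shown here alone, it remains open whether bromine itself matters, or whether chlorine or a methyl group would serve equally under the acetyl group. Going by these compounds, how 4-bromophenyl behaves without the acetyl group also remains open.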